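Chloro and Methyl on the Sulfonyl Phenyl Ring

The source may hold more compounds than are shown below. What is called first, only, known or untested is meant among the compounds shown, and "the series" means these compounds.

Measured compounds:
compound 1 `CC1CCN(c2c(S(=O)(=O)c3ccccc3)cnc3ccccc23)CC1` gives 89.2%
compound 2 `CC1CCN(c2c(S(=O)(=O)c3ccccc3)cnc3ccc(Cl)cc23)CC1` gives 59%
compound 3 `Cc1ccc(S(=O)(=O)c2cnc3ccc(C)cc3c2N2CCC(C)CC2)cc1` gives 82%

All three share one core, and in an assay on isolated protein for displacement of a labelled ligand from metabotropic glutamate receptor 5 (Homo sapiens), with a stated time of 60 min, tested at 1 uM (on this read-out higher numbers stand for more inhibition at the one concentration tested (going by the name of the read-out) and lower numbers for less inhibition), compound 1 gives 89.2%. Compound 2 carries a chloro in place of hydrogen on an aromatic carbon of that core and gives 59%, so that a number 30.2 percentage points lower from compound 1 to compound 2 (beyond the scatter). Compound 2 therefore stands lowest of the three; compound 3 gives 82%, a number clearly above compound 2, but compound 3 differs from both others in more than one place, so no single step can be read from it.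

Compound 4 `Cc1ccc(S(=O)(=O)c2cnc3ccc(Cl)cc3c2N2CCC(C)CC2)cc1Cl` keeps the chloro of compound 2 and changes the sulfonyl aryl group: 3-chloro-4-methylphenyl in place of phenyl on a sulfonyl sulfur. Within the data shown here, no measured step bears directly on this change. Among the measured compounds shown here, the only guidance is that compound 3, whose sulfonyl ring also carries a methyl, gives 82%, which shows that a substituted ring on the sulfonyl sulfur can go with a high number. The expectation for compound 4 is therefore a step of a number 3 percentage points higher from compound 2 to compound 4 (within the scatter), that is, no change beyond the scatter, with wide uncertainty. Compound 4 is estimated at 62%, between 35% and 85%.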

Compound 4, a percentage reported as inhibition, at one concentration (the size of the read-out at that concentration, not a potency): 81%
Beside the measured number, compound 4's estimate is 19 percentage points below it; low and high end bracket the measured number.
By their numbers in this assay, from the lowest: compound 2; then compounds 4, 3 and 1 (each within the scatter of the next).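

In this assay, among these compounds, putting 3-chloro-4-methylphenyl in place of phenyl on a sulfonyl sulfur gives a number 22 percentage points higher from compound 2 to compound 4 (beyond the scatter) and so supplies the first single-place step at this group. The earlier single-place step concerned only the chloro on the shared core, whereas this one shows that the number also moves with the group on the sulfonyl sulfur, even with that chloro still present. No measurement shown here accounts for the rise.

On these data alone, the chloro and the methyl enter together, so how much of the step belongs to each remains open. As far as these compounds go, it is also open how a methoxy group or an amine on that ring would read in this assay, and whether a similar step would appear on the core without the chloro.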